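From 4-hydroxycyclohexyl to oxan-4-yl: a clearance estimate

The compounds below may be only part of what the source reports. "The series", "measured", "known", "first", "only" and "open" are said of these compounds alone.

Measured so far in an in vivo ADME assay on the whole organism (strain Sprague-Dawley) for pharmacokinetics, with Rattus norvegicus as the target; on this read-out lower numbers stand for slow clearance and higher numbers for fast clearance:
- compound 1 `N#Cc1c(-c2ccc3c(ccn3[C@H]3CC[C@H](O)CC3)c2)ccn2c(CC(F)(F)F)cnc12` gives 11.7 mL/min/kg
- compound 2 `O[C@H]1CC[C@H](n2ccc3cc(-c4ccn5c(CC(F)(F)F)cnc5c4Cl)ccc32)CC1` gives 15 mL/min/kg

Going by the values given here, with only these two numbers, compound 1 has no clear rank, since the one available comparison is a 1.3-fold higher number from compound 1 to compound 2 (0.11 log units; within the scatter) and comes from chloro in place of cyano on an aromatic carbon. Compound 3 `N#Cc1c(-c2ccc3c(ccn3C3CCOCC3)c2)ccn2c(CC(F)(F)F)cnc12` keeps the core of compound 1 and instead carries oxan-4-yl in place of 4-hydroxycyclohexyl on an aromatic nitrogen, a swap counted as oxan-4-yl in place of 4-hydroxycyclohexyl on an aromatic nitrogen in full.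

The measured step lies at a different place in the molecule, so it bears on this swap only indirectly. Among the compounds with values here, no measured pair changes this group, which leaves the direction open and the range wide. What the step does show is that one change elsewhere left the number within the scatter. The expectation is therefore no step beyond the scatter, and the estimated change is a 1.4-fold higher number from compound 1 to compound 3 (0.14 log units; within the scatter) in size. For compound 3 the expected clearance is 16 mL/min/kg as a central estimate. The estimated range for compound 3 runs from 7 mL/min/kg to 35 mL/min/kg in this assay.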

Compound 3, clearance: 83.3 mL/min/kg
Beside the measured number, compound 3's estimate is 5.2-fold (0.72 log units) below it; the measured number lies above the stated range.
By their numbers in this assay, from the lowest: compounds 1 and 2 (each within the scatter of the next); then compound 3.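

The group on the aromatic nitrogen matters far more for clearance in this assay than the earlier comparison could reveal: oxan-4-yl in place of 4-hydroxycyclohexyl gives a 7.1-fold higher number from compound 1 to compound 3 (0.85 log units; beyond the scatter), whereas chloro in place of cyano on an aromatic carbon gave only a 1.3-fold higher number from compound 1 to compound 2 (0.11 log units; within the scatter). This single swap alters several features at once, as the hydrogen-bond donor and both defined stereocentres disappear and a ring of carbon only gives way to a ring holding a hetero atom, so this one pair cannot show which of these differences accounts for the rise. Nothing available here explains the rise in clearance.

The compounds shown leave open whether the same swap would produce a similar rise with chloro on the core, as in compound 2. They also leave open how clearance would respond to other groups at this nitrogen, such as a cyclohexyl ring carrying a carboxylic acid or an amine, or an open chain such as 2-hydroxyethyl.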